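Iodo in Place of Phenoxy: Expected Cytotoxicity of Compound 4

The compounds below may be only part of what the source reports. "The series", "measured", "known", "first", "only" and "open" are said of these compounds alone.

The series shares one core, carried here by compound 1 `CC(/C=N/Nc1ccc([N+](=O)[O-])cc1)=N\NC(=O)c1ccc(O)cc1`, compound 2 `CC(/C=N/Nc1ccc([N+](=O)[O-])cc1)=N\NC(=O)c1ccccc1C` and compound 3 `CC(/C=N/Nc1ccc([N+](=O)[O-])cc1)=N\NC(=O)c1ccccc1Oc1ccccc1`. In an ADME assay on J774 cells (Mus musculus, strain BALB/c) for cytotoxicity, read by resazurin assay, with a stated time of 72 h (on this read-out lower numbers stand for higher toxicity in this test and higher numbers for lower toxicity in this test), compound 1 gives 51000 nM. For compound 2 the assay reports only a limit, > 100000 nM. For compound 3 as well the assay reports only a limit, > 100000 nM. Compound 3 thus stands at the limit of this assay, as stated by the limit of > 100000 nM in this assay, at which 2 of the 3 values shown sit, and no number separates it from compound 2. The two measured steps are an at least 1.9-fold higher number from compound 1 to compound 2 (0.29 log units; that floor lies within the scatter) and a step that the two limits leave unreadable from compound 2 to compound 3; the first cannot be separated from the scatter and the second cannot be read at all.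

Compound 4 `CC(/C=N/Nc1ccc([N+](=O)[O-])cc1)=N\NC(=O)c1ccccc1I` differs from compound 3 by iodo in place of phenoxy on an aromatic carbon. Neither measured step involves an iodo group, and both end at the limit, so the measured compounds offer no readable step of any size in this assay to carry over. The step expected from compound 3 to compound 4 is therefore a number no higher from compound 3 to compound 4 (the limit leaves the size open), no change beyond the scatter, with another limit the likely outcome. Compound 4 is estimated in this assay at 100000 nM, within a range from 40000 nM to 250000 nM.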

Compound 4, half-maximal cytotoxic concentration: 40000 nM
Compound 4: middle estimate off by 2.5-fold (0.40 log units), on the high side, and the stated range covers the measured number.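

On this aromatic carbon, ortho to a large group, the substituent does make a readable difference in this assay: iodo gives an at least 2.5-fold lower number from compound 3 to compound 4 (0.39 log units; beyond the scatter), and in place of methyl it gives an at least 2.5-fold lower number from compound 2 to compound 4 (0.39 log units; beyond the scatter). Among the compounds shown here, these are the first steps at this position that lie beyond the scatter, yet each gives only a floor, and the true size stays open because compound 2 and compound 3 each carry only a limit: the limit of > 100000 nM in this assay, at which 2 of the 4 values shown sit. The third step, a 1.3-fold lower number from compound 1 to compound 4 (0.11 log units; within the scatter), shows that compound 4, with its 2-iodophenyl group, cannot be told apart from compound 1, with its 4-hydroxyphenyl group, so two quite different groups on the carbonyl carbon give values within the scatter of each other.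

The compounds shown leave open whether this drop belongs to iodo alone or would also appear with bromo, chloro or an amine on the same aromatic carbon. They also leave open how large the steps from compound 2 and compound 3 really are, since neither compound has a number to set against that of compound 4.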